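This account rests on a few compounds, and the source may have more. Where it says the series, first, only, none or still open, it means among the compounds named here.

Measured compounds in a functional assay on U-251 cells (Homo sapiens) for inhibition, read by sulforhodamine B assay, with a stated time of 48 h, tested at 10 uM; on this read-out higher numbers stand for more inhibition at the one concentration tested (going by the name of the read-out) and lower numbers for less inhibition:
compound 1 `Brc1cn2ccnc2c(-c2ccc3ncn(C4CCCCC4)c3c2)n1`: 1.5%
compound 2 `c1ccc(-c2cn3ccnc3c(-c3ccc4ncn(C5CCCCC5)c4c3)n2)cc1`: 37.3%
compound 3 `CC(=O)c1ccc(-c2cn3ccnc3c(-c3ccc4ncn(C5CCCCC5)c4c3)n2)cc1`: 3.02%

Compound 3 sits second highest of the three numbers; its value and that of compound 1 lie within the scatter of each other, while compound 2 stands well apart, as shown by a number 34.3 percentage points lower from compound 2 to compound 3 (beyond the scatter). The remaining steps are a number 35.8 percentage points higher from compound 1 to compound 2 (beyond the scatter) and a number 1.5 percentage points higher from compound 1 to compound 3 (within the scatter). Compound 4 `Clc1ccc(-c2cn3ccnc3c(-c3ccc4ncn(C5CCCCC5)c4c3)n2)cc1` is not yet measured. It differs from compound 3 by chloro in place of acetyl on an aromatic carbon. Among the measured compounds shown here, the step that bears most directly is the one from compound 2 to compound 3, where acetyl in place of hydrogen went with a large drop; in compound 4 the acetyl leaves again, and the single chlorine atom that enters has no counterpart among the measured compounds. Removal of the acetyl is therefore expected to recover much of the gap toward compound 2, though nothing measured says whether chloro behaves like hydrogen there. Compound 4 is expected to give 25% (range 5% to 45%), an estimated step of a number 22 percentage points higher from compound 3 to compound 4 (beyond the scatter).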

Compound 4, a percentage reported as inhibition, at one concentration (the size of the read-out at that concentration, not a potency): 11.3%
The estimate for compound 4 lay 13.7 percentage points above the measured number, within the range that was stated.
By their numbers in this assay, from the lowest: compounds 1, 3 and 4 (each within the scatter of the next); then compound 2.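

In this assay, the large drop seen with acetyl on the phenyl ring of compound 2 turns out not to be particular to acetyl: chloro at the same place, para to a large group, goes with a number 26 percentage points lower from compound 2 to compound 4 (beyond the scatter) as well. Chloro in place of acetyl gives a number 8.3 percentage points higher from compound 3 to compound 4 (within the scatter), and 4-chlorophenyl in place of bromo gives a number 9.8 percentage points higher from compound 1 to compound 4 (within the scatter), so of the compounds shown only compound 2, with its plain phenyl, stands apart from the rest. Nothing at hand explains why either group goes with the lower number.

Open, from the compounds shown here alone, is whether any group at this place keeps the number of compound 2, or only hydrogen does. A methyl, a fluoro or an amine there would show whether the drop follows every substituent or only chloro and acetyl.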